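Guanidinylhydrazone series: removing thiophene methyls

A few compounds are considered here, and "the series" means these few. Any claim that something is new, unique, unknown or untested is made for them only; others in the source may bear on it.

Measured so far:
compound 1 `Cc1cc(-c2nc3sc(C)cn3c2/C=N/NC(=N)N)c(C)s1` — 12000 nM
compound 2 `Cc1cn2c(/C=N/Nc3ccccn3)c(-c3ccc(Cl)c([N+](=O)[O-])c3)nc2s1` — 9120 nM

In a functional assay on cells (Cancer cell lines, Homo sapiens) for inhibition (a higher number here means a weaker inhibitor of growth, a lower number a stronger inhibitor of growth), compound 1 gives 12000 nM. Compound 2 gives 9120 nM in this assay, and the two values lie within the scatter of each other; no order between them can be drawn. Among the compounds with values here, no step between measured compounds that differ in one place is available.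

Compound 3 `Cc1cn2c(/C=N/NC(=N)N)c(-c3ccsc3)nc2s1` carries the change (thiophen-3-yl in place of 2,5-dimethylthiophen-3-yl on an aromatic carbon). Nothing measured here speaks to this change, so the step of a 1.2-fold higher number from compound 1 to compound 3 (0.07 log units; within the scatter) is expected to be small, in either direction, and likely within the scatter. For compound 3 the estimate in this assay is 14000 nM, with a range from 5000 nM to 40000 nM.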

Compound 3, concentration for 50% growth inhibition: 11000 nM
Compound 3: middle estimate off by 1.3-fold (0.10 log units), on the high side, and the stated range covers the measured number.
By their numbers in this assay, from the lowest: compounds 2, 3 and 1 (each within the scatter of the next).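

In this assay, within the data shown here, thiophen-3-yl in place of 2,5-dimethylthiophen-3-yl on this aromatic carbon gives a 1.1-fold lower number from compound 1 to compound 3 (0.04 log units; within the scatter) as the first one-place comparison. The two methyl groups on the thiophene can therefore be dropped at this position with no readable shift in growth inhibition. No available evidence bears on this result.

Still open, on these data alone, is whether any substituent on this thiophene moves the number beyond the scatter, for example an amine, a carboxylic acid or a longer alkyl chain. Also open, as far as these compounds go, is whether a saturated ring such as morpholine can take the place of the thiophene on this carbon.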